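The compounds below may be only part of what the source reports. "The series", "measured", "known", "first", "only" and "open" are said of these compounds alone.

Working notes on the series.

Compound 2 `Nc1nc2c(c(-c3cccs3)cn2[C@@H]2O[C@H](CO)[C@@H](O)[C@H]2O)c(=O)[nH]1` is the reference for the present step. In a functional assay on K562 cells (Homo sapiens), read by MTT assay, with a stated time of 72 h (on this read-out lower numbers stand for stronger inhibition and higher numbers for weaker inhibition), compound 2 gives 16800 nM, the highest of the two numbers recorded. Compound 3 `Cc1nc(N)c2c(I)cn([C@@H]3O[C@H](CO)[C@@H](O)[C@H]3O)c2n1` gives 1110 nM in this assay. Compound 1 `O=c1[nH]cnc2c1c(-c1cccs1)cn2[C@@H]1O[C@H](CO)[C@@H](O)[C@H]1O` reaches only a limit of this assay, > 20000 nM; this is the limit of > 20000 nM in this assay, at which 1 of the 3 values shown sits, and not a number.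

For the measured compounds named here, the single measured step in this assay is an at least 1.1-fold lower number from compound 1 to compound 2 (0.07 log units; that floor lies within the scatter), amino in place of hydrogen on an aromatic carbon; it concerns a different position from the change examined here and so bears on it only weakly.

Compound 4 `Nc1nc2c(c(-c3ccsc3)cn2[C@@H]2O[C@H](CO)[C@@H](O)[C@H]2O)c(=O)[nH]1` is not yet measured. Its difference from compound 2 is thiophen-3-yl in place of thiophen-2-yl on an aromatic carbon. Going by the values given here, no measured step touches this thiophene position, so there is no basis for expecting a shift beyond the scatter in either direction. The expected step is therefore a 1.1-fold lower number from compound 2 to compound 4 (0.05 log units; within the scatter), within the scatter. On that basis compound 4 is estimated at 15000 nM, with a range from 6000 nM to 40000 nM in this assay.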

Compound 4, half-maximal inhibitory concentration: 18300 nM
Estimate against measurement, compound 4: 1.2-fold (0.09 log units) below; the range from low to high includes it.
By their numbers in this assay, from the lowest: compound 3; then compounds 2 and 4 (each within the scatter of the next). At a limit, above all of these: compound 1.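

In this assay, for the compounds shown here, moving the point of attachment from thiophen-2-yl to thiophen-3-yl gives a 1.1-fold higher number from compound 2 to compound 4 (0.04 log units; within the scatter) and is the first reading at this position. The two groups have the same atoms and the same counts of donors and acceptors, and on this read-out compound 2 and compound 4 cannot be told apart, so the attachment point of the thiophene alone does not register on the core of compound 2. Nothing on hand accounts for this absence of a shift.

From the compounds shown here alone, how this aromatic carbon responds to a group other than a thiophene, such as phenyl, furan-2-yl or an aminomethyl chain, remains open. Also open, going by these compounds, is whether thiophen-3-yl would read the same on the core of compound 1, whose thiophen-2-yl form stands only at a limit of the assay.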